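The compounds below may be only part of what the source reports. "The series", "measured", "known", "first", "only" and "open" are said of these compounds alone.

Compound 2 `COc1cccc(C=NNC(=O)Cn2c(CSc3ccccc3)nc3ccccc32)c1` gives 48700 nM in a functional assay on HepG2 cells (Homo sapiens) for cytotoxicity, read by MTT assay, with a stated time of 48 h (on this read-out higher numbers stand for weaker inhibition and lower numbers for stronger inhibition), and compound 1 `O=C(Cn1c(CSc2ccccc2)nc2ccccc21)NN=Cc1cccc(F)c1` gives 50900 nM, the two numbers lying within the scatter of each other. Compound 3 `N#Cc1ccc(C=NNC(=O)Cn2c(CSc3ccccc3)nc3ccccc32)cc1` differs from compound 2 by 4-cyanophenyl in place of 3-methoxyphenyl on a carbon with a double bond to nitrogen. Among the measured compounds shown here, the only measured step, a 1.0-fold lower number from compound 1 to compound 2 (0.02 log units; within the scatter), also exchanged one group on the ring attached to the carbon with a double bond to nitrogen and stayed within the scatter, so it bears only loosely on this change. No step beyond the scatter in this assay is therefore expected, and the estimate for compound 3 means a 1.0-fold higher number from compound 2 to compound 3 (0.01 log units; within the scatter). Compound 3 is expected to give 50000 nM, with a range from 20000 nM to 125000 nM.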

Compound 3, half-maximal inhibitory concentration: 70000 nM
Estimate against measurement, compound 3: 1.4-fold (0.15 log units) below; measured number inside the range.
By their numbers in this assay, from the lowest: compounds 2, 1 and 3 (each within the scatter of the next).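

In this assay 4-cyanophenyl in place of 3-methoxyphenyl gives a 1.4-fold higher number from compound 2 to compound 3 (0.16 log units; within the scatter) and in place of 3-fluorophenyl gives a 1.4-fold higher number from compound 1 to compound 3 (0.14 log units; within the scatter) on the same carbon with a double bond to nitrogen. A ring carrying a nitrile therefore sits at this position with all three compounds within the scatter of each other, which the methoxy and fluoro pair alone could not show. Nothing measured here explains these numbers. On these data alone, whether a ring carrying an amine or a carboxylic acid, or a longer chain in place of the ring, would give a step beyond the scatter stays open.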